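Nitro for methoxycarbonyl: expectation for compound 3

This account rests on a few compounds, and the source may have more. Where it says the series, first, only, none or still open, it means among the compounds named here.

Measured so far, with structures and values:
compound 1 `COc1ccc(CNc2cc(OC)c(OC)c(OC)c2)cc1C` — 56800 nM
compound 2 `COC(=O)c1cc(CNc2cc(OC)c(OC)c(OC)c2)ccc1OC` — 49600 nM
compound 3 `COc1ccc(CNc2cc(OC)c(OC)c(OC)c2)cc1[N+](=O)[O-]` — not yet measured

In a functional assay on MGC-803 cells (Homo sapiens) for inhibition, read by MTT assay, with a stated time of 48 h (a lower number here means a stronger inhibitor, a higher number a weaker inhibitor), compound 1 gives 56800 nM and compound 2 gives 49600 nM. Going by the values given here, the only step measured, a 1.1-fold lower number from compound 1 to compound 2 (0.06 log units; within the scatter), puts the two within the scatter of each other, so compound 2 stands where compound 1 stands and neither can be ranked against the other.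

Compound 3 differs from compound 2 by nitro in place of methoxycarbonyl on an aromatic carbon. Among the compounds with values here, the one step that bears on this place is a 1.1-fold lower number from compound 1 to compound 2 (0.06 log units; within the scatter), which exchanged groups at the same aromatic carbon and left the number unchanged beyond the scatter. On that single comparison there is no sign that the group at this carbon moves the read-out, so no step beyond the scatter is expected for compound 3 in this assay, in either direction.

Compound 3 is therefore estimated at 50000 nM, with a range from 20000 nM to 125000 nM. The expected step of a 1.0-fold higher number from compound 2 to compound 3 (0.00 log units; within the scatter) is within the scatter. This rests on a single comparison and the number may fall outside it.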

Compound 3, half-maximal inhibitory concentration: 19400 nM
Estimate against measurement, compound 3: 2.6-fold (0.41 log units) above; measured number below the stated range.
By their numbers in this assay, from the lowest: compound 3; then compounds 2 and 1 (each within the scatter of the next).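

In this assay, the group at this aromatic carbon, ortho to a methoxy group, can shift the number after all: nitro in place of methoxycarbonyl gives a 2.6-fold lower number from compound 2 to compound 3 (0.41 log units; beyond the scatter) and nitro in place of methyl gives a 2.9-fold lower number from compound 1 to compound 3 (0.47 log units; beyond the scatter), while methyl and methoxycarbonyl could not be told apart. The position is therefore not indifferent to substitution, although among the three groups shown only nitro separates from the others, and both of its steps are modest. Nothing measured here accounts for these steps, so the shift cannot be tied to any particular feature of the nitro group.

Three groups at one carbon cannot show whether an amine, a carboxylic acid or a hydroxyl group would follow nitro to a lower number or stay level with methyl and methoxycarbonyl. On these data alone, it also remains open whether nitro would give a similar step at another carbon of the same ring, or whether the step would persist if the methoxy group beside which this change was read were replaced by a longer chain.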